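Cytotoxicity of a Lactone Isomer Swap in Two Cores

The source may report more compounds than this note shows. Statements on the series, on what has been measured and on what is new or still open speak of the compounds shown alone.

The measured compounds and their values:

Compound 1 `C=C1CC[C@@H]2[C@](C)(COC(=O)/C=C/c3cc(OC)c(OC)c(OC)c3)[C@H](O)CC[C@@]2(C)[C@@H]1/C=C/C1=CCOC1=O`: > 1700000 nM
Compound 2 `C=C1CC[C@@H]2[C@](C)(COC(=O)/C=C/c3cc(OC)c(OC)c(OC)c3)[C@H](O)CC[C@@]2(C)[C@@H]1C/C=C1\C=COC1=O`: 325000 nM
Compound 3 `C=C1CC[C@H]2[C@@](C)(CCC(=O)[C@@]2(C)C=O)[C@@H]1/C=C/C1=CCOC1=O`: 275000 nM

Compound 1 carries a lactone side group on the shared core, and in an ADME assay on HepG2 2.2.15 cells (Homo sapiens) for cytotoxicity, read by MTT assay (on this read-out higher numbers stand for lower toxicity in this test and lower numbers for higher toxicity in this test), compound 1 reaches only a limit of the test, (the limit of > 1700000 nM in this assay, at which 1 of the 3 values shown sits). Compound 2 has the same atoms joined differently: a group of 8 heavy atoms (6 carbon, 2 oxygen; one five-membered non-aromatic ring with 1 hetero atom) in place of a group of 8 heavy atoms (6 carbon, 2 oxygen; one five-membered non-aromatic ring with 1 hetero atom), on a saturated ring carbon. This change gives an at least 5.2-fold lower number from compound 1 to compound 2 (0.71 log units; beyond the scatter), so compound 2 is read as more toxic in this assay.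

Compound 3 has a different core, with a ketone and an aldehyde in place of the ester-bearing side chain and hydroxyl of compound 1; the difference between the two cores is not broken down here. In this assay compound 3 gives 275000 nM, a number within the scatter of that of compound 2.

Compound 4 `C=C1CC[C@H]2[C@@](C)(CCC(=O)[C@@]2(C)C=O)[C@@H]1C/C=C1\C=COC1=O` is not yet measured. It differs from compound 3 in the same way that compound 2 differs from compound 1: a group of 8 heavy atoms (6 carbon, 2 oxygen; one five-membered non-aromatic ring with 1 hetero atom) in place of a group of 8 heavy atoms (6 carbon, 2 oxygen; one five-membered non-aromatic ring with 1 hetero atom), on a saturated ring carbon. Since the change from compound 1 to compound 2 produced an at least 5.2-fold lower number from compound 1 to compound 2 (0.71 log units; beyond the scatter), the same kind of change on the core of compound 3 is expected to lower the number again, giving an estimated 4.2-fold lower number from compound 3 to compound 4 (0.63 log units; beyond the scatter). The first step is known only as a limit. Its true size is uncertain, so the estimate is wide. Compound 4 is therefore expected to give about 65000 nM in this assay, with a likely range from 20000 nM to 230000 nM.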

Compound 4, half-maximal cytotoxic concentration: 964000 nM
Compound 4: middle estimate off by 15-fold (1.17 log units), on the low side, outside the stated range (above it).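

On the second core the same swap of lactone side groups runs the opposite way in this assay, with a 3.5-fold higher number from compound 3 to compound 4 (0.54 log units; beyond the scatter), and this reads as lower toxicity in this test. The effect of the change therefore does not carry over from one core to the other in these two pairs, and what was seen on the first core gave no safe guide to the direction on the second: the same change on two cores in this assay, an at least 5.2-fold lower number (0.71 log units; beyond the scatter) from compound 1 to compound 2 and a 3.5-fold higher number (0.54 log units; beyond the scatter) from compound 3 to compound 4, at least 18-fold (1.26 log units) apart, beyond the scatter of two such steps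

This does not show which feature of the cores reverses the step, nor how large the first step truly is, since compound 1 stands at a limit of the test and not at a number: the limit of > 1700000 nM in this assay, at which 1 of the 4 values shown sits.

Two pairs also cannot say which core's behaviour is the more usual one, or whether the ketone, the aldehyde, the hydroxyl or the ester-bearing side chain goes with the reversal, as these all differ at once between the cores. Also open is how the swap would behave on a core carrying a carboxylic acid or an amine in place of the aldehyde, where neither direction can be assumed from the compounds shown.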